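Swapping the thiophene for a short alkyl chain

The source may hold more compounds than are shown below. What is called first, only, known or untested is meant among the compounds shown, and "the series" means these compounds.

Compound 1, `COc1cc(N)c(Cl)cc1NC(=O)C1CCN(CC2CC2)CC1` — > 10 mg/kg
Compound 2, `COc1cc(N)c(Cl)cc1NC(=O)C1CCN(Cc2ccsc2)CC1` — 3.4 mg/kg

Among the measured compounds shown here, in a functional assay on the whole organism for antagonist activity, with Mus musculus as the target (a higher number here means that more compound is needed for the effect, a lower number that less compound is needed), compound 2 gives 3.4 mg/kg, the only numerical value available. Compound 1 yields only a limit, > 10 mg/kg. Compound 3, `CCCN1CCC(C(=O)Nc2cc(Cl)c(N)cc2OC)CC1`, differs from compound 2 by ethyl in place of thiophen-3-yl on a saturated chain carbon bound to an amine nitrogen in a ring. For the measured compounds named here, the one measured step, an at least 2.9-fold lower number from compound 1 to compound 2 (0.46 log units; beyond the scatter), runs the opposite way, from a small alkyl group to the thiophene, and compound 1 sits at the limit of > 10 mg/kg in this assay, at which 1 of the 2 values shown sits. Removing the thiophene again is therefore expected to raise the dose, with an estimated step of a 2.9-fold higher number from compound 2 to compound 3 (0.47 log units; beyond the scatter). For compound 3 the estimate is 10 mg/kg, between 4 mg/kg and 25 mg/kg.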

Compound 3, dose for half-maximal effect: > 10 mg/kg
Compound 3 was reported as a limit; the forecaster's own chance of this, stated with the estimate: 50%; the middle value lies on the limit itself.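

In this assay, the thiophen-3-yl group now stands apart from ethyl as well as from cyclopropyl at this place, on a saturated chain carbon bound to an amine nitrogen in a ring, with an at least 2.9-fold higher number from compound 2 to compound 3 (0.46 log units; beyond the scatter). The value of compound 3 is a limit, not a number, and it is the same limit as for compound 1: the limit of > 10 mg/kg in this assay, at which 2 of the 3 values shown sit.

As far as these compounds go, the step between those two compounds therefore cannot be read, so how ethyl and cyclopropyl rank remains unknown. From the compounds shown here alone, whether phenyl or furan-3-yl would match the thiophen-3-yl group at this place stays open.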